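Swapping the aryl group on the amide-type nitrogen of compound 3

The compounds below may be only part of what the source reports. "The series", "measured", "known", "first", "only" and "open" are said of these compounds alone.

In a functional assay on HUVEC cells (Homo sapiens) for inhibition (a higher number here means a weaker inhibitor, a lower number a stronger inhibitor), compound 1 (`CN(c1ccc(NC(=O)Nc2ccccc2)cc1)c1ccnc(Nc2cccc(CS(C)(=O)=O)c2)n1`) gives 0.2 nM, compound 2 (`CN(c1ccc(NS(=O)(=O)Cc2ccccc2)cc1)c1ccnc(Nc2cccc(CS(C)(=O)=O)c2)n1`) gives 350 nM and compound 3 (`CN(c1ccc(NC(=O)Nc2ccc(OC(F)(F)F)cc2)cc1)c1ccnc(Nc2cccc(CS(C)(=O)=O)c2)n1`) gives 7 nM. Compound 3 therefore holds the middle of the three numbers, with compound 1 lower and compound 2 higher.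

Compound 4 (`CN(C)CCNC(=O)Nc1ccc(N(C)c2ccnc(Nc3cccc(CS(C)(=O)=O)c3)n2)cc1`) remains unmeasured. It carries 2-(dimethylamino)ethyl in place of 4-(trifluoromethoxy)phenyl on an amide-type nitrogen.

Among the compounds with values here, two measured steps bear on this change, and both are large. Trifluoromethoxy in place of hydrogen on an aromatic carbon gives a 35-fold higher number from compound 1 to compound 3 (1.54 log units; beyond the scatter). Benzylsulfonyl in place of phenylcarbamoyl on a nitrogen on an aromatic ring gives a 1800-fold higher number from compound 1 to compound 2 (3.24 log units; beyond the scatter). Within the data shown here, neither is a direct precedent, as no measured compound has a ringless chain on this nitrogen.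

The wider replacement in compound 2, at 350 nM, points towards a higher number. Compound 1, at 0.2 nM, shows that a number can also fall when trifluoromethoxy is absent, so the range stays wide on both sides. A moderate rise is expected, estimated as a 4.3-fold higher number from compound 3 to compound 4 (0.63 log units; beyond the scatter). For compound 4 the estimated value is 30 nM, with an expected range of 3 nM to 300 nM.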

Compound 4, half-maximal inhibitory concentration: 530 nM
Beside the measured number, compound 4's estimate is 18-fold (1.25 log units) below it, and the stated range ends below it.
By their numbers in this assay, from the lowest: compound 1; then compound 3; then compounds 2 and 4 (each within the scatter of the next).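

In this assay, within the data shown here, 2-(dimethylamino)ethyl is the first ringless group on the amide-type nitrogen, and it gives a 76-fold higher number from compound 3 to compound 4 (1.88 log units; beyond the scatter), while the step from the unsubstituted phenyl group is a 2700-fold higher number from compound 1 to compound 4 (3.42 log units; beyond the scatter). The carbamoyl link on the shared core is kept in this change, yet the result sits level with the benzylsulfonyl compound, at a 1.5-fold higher number from compound 2 to compound 4 (0.18 log units; within the scatter), so among these compounds that link alone does not secure a low number. No measurement on these groups is available that would account for the loss of inhibition.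

The change removes the aromatic ring and brings in the dimethylamino nitrogen at once, so the compounds shown cannot separate these two parts of the replacement. A plain butyl chain or a benzyl group on the same nitrogen would bear on the ring, a 2-methoxyethyl chain would bear on the terminal amine, and a longer chain carrying the same amine would show whether distance from the carbonyl matters.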